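Phenyl in place of ethoxycarbonyl, made a second time

This account rests on a few compounds, and the source may have more. Where it says the series, first, only, none or still open, it means among the compounds named here.

Compound 1, `CCOC(=O)/C=N/c1cnc(Nc2ccc(N3CCN(C)CC3)cc2)nc1NC1CCCC1`, gives 15100 nM in a functional assay on HT-29 cells (Homo sapiens) for antiproliferative activity, read by MTT assay; a higher number here means a weaker inhibitor, a lower number a stronger inhibitor.
Compound 2, `CN1CCN(c2ccc(Nc3ncc(/N=C/c4ccccc4)c(NC4CCCC4)n3)cc2)CC1`, gives 28600 nM in this assay.
Compound 3, `CCOC(=O)/C=N/c1cnc(Nc2ccc(S(N)(=O)=O)cc2)nc1NC(C)C`, gives in this assay only a limit of the assay, > 100000 nM.

Compound 1 and compound 2 share a core and differ in one place: phenyl in place of ethoxycarbonyl on a carbon with a double bond to nitrogen. The step that goes with this change is a 1.9-fold higher number from compound 1 to compound 2 (0.28 log units; within the scatter), so the two values cannot be told apart. Compound 3 is built on a different core; how the two cores differ is not broken down here. Compound 3 is one of the values that sit at the limit of > 100000 nM in this assay, at which 1 of the 3 values shown sits, so it is known only as a limit and not as a number.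

Compound 4, `CC(C)Nc1nc(Nc2ccc(S(N)(=O)=O)cc2)ncc1/N=C/c1ccccc1`, is not yet measured. It arises from compound 3 by phenyl in place of ethoxycarbonyl on a carbon with a double bond to nitrogen, and the place of the change reads the same as in the step from compound 1 to compound 2, so it is the same change made on the other core.

For compound 4 a step that the limit leaves unreadable from compound 3 to compound 4 is expected, resting on the earlier step of a 1.9-fold higher number from compound 1 to compound 2 (0.28 log units; within the scatter), which stayed within the scatter. Since compound 3 sits at the limit, compound 4 is expected to remain at or near that limit as well. The estimate for compound 4 is 150000 nM, with a range from 50000 nM to 500000 nM.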

Compound 4, half-maximal inhibitory concentration: 98200 nM
Estimate against measurement, compound 4: 1.5-fold (0.18 log units) above; low and high end bracket the measured number.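

In this assay, compound 3 gives > 100000 nM, which is a limit of the assay and not a number. From the compounds shown here alone, the step for phenyl in place of ethoxycarbonyl on this core can therefore be given only as a floor, an at least 1.0-fold lower number from compound 3 to compound 4 (0.00 log units; that floor lies within the scatter), and the true size of the step stays unknown, although compound 4 itself has a real number that can serve as a reference for later work. This shows that the change can be placed on both cores and read in the same assay, but it does not show that the change has the same effect on both, nor that its effect differs between them: the same change on two cores in this assay, a 1.9-fold higher number (0.28 log units; within the scatter) from compound 1 to compound 2 and an at least 1.0-fold lower number (0.00 log units; that floor lies within the scatter) from compound 3 to compound 4; the limit leaves it open whether they differ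

The compounds shown leave open how other groups would behave on a carbon with a double bond to nitrogen, such as a carboxylic acid, an amide or a longer carbon chain in place of the ethoxycarbonyl. For the compounds shown here, they also leave open whether the change would give a matching step on a core where both partners have real numbers, since only two cores appear here and only one of the two steps has a fully measured size.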